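Enlarging the hydroxylated ring on the shared core

A few compounds are considered here, and "the series" means these few. Any claim that something is new, unique, unknown or untested is made for them only; others in the source may bear on it.

Compound 1 `N#Cc1cnc(NCc2cnccc2C(F)(F)F)cc1NC[C@H]1C[C@H](O)C1` was tested in an assay on isolated protein for inhibition of protein kinase C delta type (Homo sapiens), read by TR-FRET, with a stated time of 2 h; on this read-out lower numbers stand for stronger inhibition and higher numbers for weaker inhibition. In this assay compound 1 gives > 10000 nM, which is a limit of the assay rather than a number. Within the data shown here, compound 2 `N#Cc1cnc(NCc2ccccc2)cc1N[C@H]1CC[C@@H](O)CC1` differs from compound 1 in more than one place, so no single step joins the two. In this assay compound 2 gives > 10000 nM, again a limit and not a measured number. Among the measured compounds shown here, compound 1 therefore sits at the same limit as the only other value shown (the limit of > 10000 nM in this assay, at which 2 of the 2 values shown sit), and nothing in these numbers separates the two compounds.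

Compound 3 `CC1(C)C[C@@H](Nc2cc(NCc3cnccc3C(F)(F)F)ncc2C#N)CC[C@H]1O` has not yet been measured. It differs from compound 1 in one place: 4-hydroxy-3,3-dimethylcyclohexyl in place of (3-hydroxycyclobutyl)methyl on a nitrogen on an aromatic ring. For the measured compounds named here, with both known values resting at a limit, there is no measured step that shows how such a change moves the read-out, and any expectation rests on the limit alone. The step from compound 1 to compound 3 is expected to be an at least 1.2-fold lower number from compound 1 to compound 3 (0.09 log units; that floor lies within the scatter), most likely leaving the value at or close to the limit. For compound 3 the estimate in this assay is 8000 nM, with a range from 1500 nM to 30000 nM.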

Compound 3, half-maximal inhibitory concentration: 2400 nM
Estimate against measurement, compound 3: 3.3-fold (0.52 log units) above; low and high end bracket the measured number.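

In this assay, the group on a nitrogen on an aromatic ring proves able to move the read-out: 4-hydroxy-3,3-dimethylcyclohexyl in place of (3-hydroxycyclobutyl)methyl gives an at least 4.1-fold lower number from compound 1 to compound 3 (0.61 log units; beyond the scatter). This step starts from a limit rather than a number, so its size is a floor and the true gap could be wider. The earlier compounds could not show any such difference, and compound 3 is the only one of the three with a measured number rather than a limit: the limit of > 10000 nM in this assay, at which 2 of the 3 values shown sit.

The step changes several things at once, since a six-membered ring replaces a four-membered one, two methyl groups enter and the carbon link between ring and nitrogen is gone, and the compounds shown do not say which of these changes carries the gain. They also leave open what the hydroxyl contributes at this position, a question that an amine or a methoxy group on the same dimethylcyclohexyl ring would address.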